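Replacing the 1H-1,2,4-triazol-1-yl group of compound 1

The source may hold more compounds than are shown below. What is called first, only, known or untested is meant among the compounds shown, and "the series" means these compounds.

Measured so far in a physicochemical assay for lipophilicity, at pH 7.4; on this read-out higher numbers stand for higher lipophilicity and lower numbers for lower lipophilicity:
- compound 1 `CC(C)Oc1ccc(-c2nnc(-n3cncn3)s2)cc1Cl`: 6.18
- compound 2 `CC(C)Oc1ccc(-c2nnc(-n3cc4c(n3)CCN(CCCC(=O)O)C4)s2)cc1Cl`: 3.56

Of these two, compound 1 stands highest, and compound 2 lies lower by more than the usual scatter. Compound 3 `CC(C)Oc1ccc(-c2nnc(-c3ccnn3C)s2)cc1Cl` has not yet been measured. It carries 1-methyl-1H-pyrazol-5-yl in place of 1H-1,2,4-triazol-1-yl on an aromatic carbon. Among the compounds with values here, no measured pair shows this change on its own, so only a small upward step in this assay is expected, possibly none beyond the scatter. The starting point is compound 1 at 6.18 on this scale. The estimated step is a number 0.12 log units higher from compound 1 to compound 3 (within the scatter) (an expectation only). For compound 3 the estimated value is 6.3 (expected range 5.8 to 6.8).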

Compound 3, distribution coefficient: 7.04
Estimate against measurement, compound 3: 0.74 log units below; the whole stated range lies below it.
By their numbers in this assay, from the lowest: compound 2; then compound 1; then compound 3.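

In this assay, putting 1-methyl-1H-pyrazol-5-yl in place of 1H-1,2,4-triazol-1-yl gives a number 0.86 log units higher from compound 1 to compound 3 (beyond the scatter) on the same core. At this position, exchanging one uncharged five-membered aromatic ring for another can therefore shift the number beyond the usual scatter. No measurement shown accounts for this rise. The compounds shown do not separate the effect of the methyl group from that of the ring itself, which a pyrazol-5-yl group without the methyl could test. As far as these compounds go, how a small non-ring group such as a nitrile would read at this position also remains open.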